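The source may hold more compounds than are shown below. What is called first, only, known or untested is meant among the compounds shown, and "the series" means these compounds.

Working notes on the series in a functional assay on TREX cells for negative allosteric modulation of metabotropic glutamate receptor 3 (Rattus norvegicus), read by calcium flux, with a stated time of 2.5 min; a higher number here means a weaker inhibitor, a lower number a stronger inhibitor. Compound 1 `COc1ccc(C#Cc2ccc(C(=O)N3CCC[C@@H](O)C3)c(F)c2)cc1` serves as the reference point: in this assay compound 1 gives 450 nM; 593 nM; 603 nM (3 entries), and the several entries of compound 1 in this assay, 450 nM; 593 nM; 603 nM (3 entries) shows how closely its repeats sit together. Within the data shown here, compound 2 `COc1ccc(C#Cc2ccc(C(=O)N3CCC(CO)C3)cc2)cc1` carries the 3-(hydroxymethyl)pyrrolidin-1-yl amide; in this assay compound 2 gives 7590 nM, the only number it has, with one further entry that returned no single number, so it stands far toward the weak end next to compound 1. Among the measured compounds shown here, no pair of measured compounds differs in a single place, so no measured step is available to lean on. Compound 3 `COc1ccc(C#Cc2ccc(C(=O)NC(C)CO)cc2)cc1` differs from compound 2 as follows: (1-(hydroxymethyl)ethyl)amino in place of 3-(hydroxymethyl)pyrrolidin-1-yl on a carbonyl carbon. With nothing measured on this type of change, the step is expected to be modest, near the scatter, if anything toward weaker inhibition. Compound 3 in this assay is estimated at 11000 nM, range 3500 nM to 30000 nM. The expected step is a 1.4-fold higher number from compound 2 to compound 3 (0.16 log units; within the scatter).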

Compound 3, half-maximal inhibitory concentration: 7590 nM
The estimate for compound 3 lay 1.4-fold (0.16 log units) above the measured number; the measured number falls inside the stated range.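

In this assay, the group on the carbonyl carbon can pass from a ring to an open chain without any visible effect: replacing 3-(hydroxymethyl)pyrrolidin-1-yl with (1-(hydroxymethyl)ethyl)amino gives no change at the digits printed from compound 2 to compound 3 (within the scatter). Among these compounds, this is the first single-place step, and it shows that, at this weak level of inhibition, the five-membered non-aromatic ring is not needed to hold the number. The precision of such a match can be judged only against the repeats available: the several entries of compound 1 in this assay, 450 nM; 593 nM; 603 nM (3 entries)

As far as these compounds go, it remains open whether a longer chain, a carboxylic acid or an amine in place of the hydroxymethyl part would move the number at this position. Among the compounds shown here, no single-place step links compound 1 to compound 2 or compound 3, so the contribution of this position to their separation remains unresolved.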